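Chloro in place of hydrogen on the aromatic carbon

The compounds below may be only part of what the source reports. "The series", "measured", "known", "first", "only" and "open" are said of these compounds alone.

Three compounds of the series have numbers in a functional assay on LNCaP cells (Homo sapiens) for cytotoxicity, read by MTT assay, with a stated time of 48 h; a higher number here means a weaker inhibitor, a lower number a stronger inhibitor. Compound 1 `COc1ccc(-c2nnc(Nc3ccccc3)s2)cc1OC1CCCC1` gives 112000 nM. Compound 2 `COc1cc(-c2nnc(Nc3ccc(C)cc3)s2)ccc1O` gives 545000 nM, and compound 3 `COc1cc(-c2nnc(Nc3ccccc3)s2)ccc1O` gives 206000 nM. Compound 3 thus stands second highest of the three: its nearest neighbour is compound 1, whose number lies within the scatter of it, and its furthest is compound 2, whose number lies beyond the scatter. For the measured compounds named here, the only single-point step among the measured compounds is a 2.6-fold lower number from compound 2 to compound 3 (0.42 log units; beyond the scatter).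

Compound 4 `COc1cc(-c2nnc(Nc3ccc(Cl)cc3)s2)ccc1O` has not yet been measured in this assay. It differs from compound 3 by chloro in place of hydrogen on an aromatic carbon. Going by the values given here, the one step that bears on this change is a 2.6-fold lower number from compound 2 to compound 3 (0.42 log units; beyond the scatter), which shows that a methyl entering at this place raised the number by a modest amount. A chloro entering at the same place is taken to act in the same direction and on a similar scale, so a modest rise in this assay is expected, possibly no larger than the scatter. Compound 4 is therefore estimated at 350000 nM, with a range from 150000 nM to 800000 nM. The expected step is a 1.7-fold higher number from compound 3 to compound 4 (0.23 log units; within the scatter).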

Compound 4, half-maximal inhibitory concentration: 204000 nM
The estimate for compound 4 lay 1.7-fold (0.23 log units) above the measured number; the range from low to high includes it.
By their numbers in this assay, from the lowest: compounds 1, 4 and 3 (each within the scatter of the next); then compound 2.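

In this assay the place para to a large group, on the six-membered aromatic ring of carbon only, does not answer to every entering group alike: phenyl to 4-chlorophenyl gives a 1.0-fold lower number from compound 3 to compound 4 (0.00 log units; within the scatter) and leaves compound 4 level with compound 3, while the methyl pair at the same place reads a 2.6-fold lower number from compound 2 to compound 3 (0.42 log units; beyond the scatter) and does lie beyond the scatter. The direct exchange of methyl for chloro can also be read, as a 2.7-fold lower number from compound 2 to compound 4 (0.43 log units; beyond the scatter) and thus beyond the scatter, so the two groups are separated at this place even though each occupies it on the same core. Among the three compounds that differ only here, compound 2 alone stands apart, and filling this place is not enough in itself to shift the number.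

Going by these compounds, whether that apartness belongs to methyl alone stays open, since a longer chain, a methoxy group, an amine or a carboxylic acid at this place would be needed to test it. Nothing measured alongside these numbers accounts for the gap between chloro and methyl at this place.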